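This account rests on a few compounds, and the source may have more. Where it says the series, first, only, none or still open, it means among the compounds named here.

In an ADME assay on H1-HeLa cells (Homo sapiens) for cytotoxicity, read by MTT assay, with a stated time of 3 days (on this read-out higher numbers stand for lower toxicity in this test and lower numbers for higher toxicity in this test), compound 3 `CNC(=O)c1cc(Oc2ccc(-c3noc(C)n3)cc2)ccn1` gives > 100000 nM, which is a limit of the assay and not a number. Compound 1 `CNC(=O)c1cc(Oc2ccc3c(C)c(-c4noc(C)n4)sc3c2)ccn1` gives > 100000 nM, which is also a limit. The shown data thus include (the limit of > 100000 nM in this assay, at which 2 of the 3 values shown sit), so compound 3 has no exact place on the scale. Compound 2 `CNC(=O)c1cc(Oc2ccc3c(C)c(-c4noc(C(C)C)n4)sc3c2)ccn1`, by contrast, gives a true number of 5500 nM.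

Compound 4 `CNC(=O)c1cc(Oc2ccc(-c3noc(C4CC4)n3)cc2)ccn1` differs from compound 3 by cyclopropyl in place of methyl on an aromatic carbon. The closest measured change is isopropyl in place of methyl on an aromatic carbon, which gave an at least 18-fold lower number from compound 1 to compound 2 (1.25 log units; beyond the scatter). That large step comes from a different core, and a different group enters, so it is only a rough guide. A step in the same direction is expected here, probably a smaller one, and compound 4 may still reach the limit. The expected step is an at least 3.3-fold lower number from compound 3 to compound 4 (0.52 log units; beyond the scatter), towards a lower number and so higher toxicity in this test. Compound 4 is estimated at 30000 nM, with an expected range from 6000 nM to 100000 nM.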

Compound 4, half-maximal cytotoxic concentration: 32300 nM
Compound 4: middle estimate off by 1.1-fold (0.03 log units), on the low side, and the stated range covers the measured number.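

Going from 5-methyl-1,2,4-oxadiazol-3-yl to 5-cyclopropyl-1,2,4-oxadiazol-3-yl gives, in this assay, an at least 3.0-fold lower number from compound 3 to compound 4 (0.49 log units; beyond the scatter), a shift towards higher toxicity in this test. Until now, only the core of compound 1 had shown such a shift when a larger group replaced methyl, so the direction now holds in two pairs, on two cores and with two different groups. The true size of neither step can be fixed, and the two cannot be ranked, because each starts from a limit: the limit of > 100000 nM in this assay, at which 2 of the 4 values shown sit.

Going by these compounds, whether isopropyl on the core of compound 3, or cyclopropyl on the core of compound 1, would behave in the same way remains open. So does the effect of an amine, a carboxylic acid or a longer chain at this place.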